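Swapping the ethoxy for trifluoromethoxy on the biaryl tail

The source may hold more compounds than are shown below. What is called first, only, known or untested is meant among the compounds shown, and "the series" means these compounds.

Measured so far:
Compound 1, `CC[C@H](C)[C@H](N)CN(C(=O)[C@@H]1C[C@H]1c1ccccc1)c1ccc(-c2ccc(C(C)(C)C)cc2)cc1`, 750 nM
Compound 2, `CCOc1ccc(-c2ccc(N(C[C@@H](N)[C@@H](C)CC)C(=O)[C@@H]3C[C@H]3c3ccccc3)cc2)cc1`, 90 nM

Both compounds were tested in a functional assay for agonist activity at G protein-coupled receptor 88 (Homo sapiens), read by HTRF and cAMP accumulation; a lower number here means that less compound is needed, a higher number that more compound is needed for the effect. Among the compounds with values here, compound 2 holds the lowest of the two numbers known so far, with compound 1 the nearest neighbour at a number an 8.3-fold lower number from compound 1 to compound 2 (0.92 log units; beyond the scatter) away, the only measured step and the one that bears on what follows.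

Compound 3, `CC[C@H](C)[C@H](N)CN(C(=O)[C@@H]1C[C@H]1c1ccccc1)c1ccc(-c2ccc(OC(F)(F)F)cc2)cc1`, differs from compound 2 only in one place: trifluoromethyl in place of ethyl on an oxygen on an aromatic ring. Within the data shown here, no measured step touches this exact exchange; the single known step, ethoxy in place of tert-butyl, speaks only to the ethoxy end. On that basis a modest step in either direction would not surprise, and a small loss is taken as the central expectation, a 2.2-fold higher number from compound 2 to compound 3 (0.35 log units; beyond the scatter). Compound 3 is therefore expected at about 200 nM, in the range 60 nM to 700 nM.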

Compound 3, half-maximal effective concentration: 170 nM
Estimate against measurement, compound 3: 1.2-fold (0.07 log units) above, and the stated range covers the measured number.
By their numbers in this assay, from the lowest: compounds 2 and 3 (each within the scatter of the next); then compound 1.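

The exchange of ethyl for trifluoromethyl on the oxygen leaves the reading in this assay essentially in place (a 1.9-fold higher number from compound 2 to compound 3 (0.28 log units; within the scatter)), so at this position the ethoxy group can give way to trifluoromethoxy, with its fluorine atoms in place of the ethyl carbons, without a step beyond the scatter. Trifluoromethoxy also keeps a clear distance from tert-butyl (a 4.4-fold lower number from compound 1 to compound 3 (0.64 log units; beyond the scatter)), and with compound 2 and compound 3 both on the same side of compound 1, the earlier difference no longer rests on ethoxy alone. Nothing available bears on why these two groups read alike.

What the compounds shown leave open is whether the oxygen itself matters, which a plain trifluoromethyl or ethyl group on the aromatic carbon would test. A longer chain on the oxygen, such as propyl, or an amine at this place also remains an open question.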